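A few compounds are considered here, and "the series" means these few. Any claim that something is new, unique, unknown or untested is made for them only; others in the source may bear on it.

In an ADME assay on HepG2 cells (Homo sapiens) for cytotoxicity (a higher number here means that more compound is tolerated, a lower number that less compound is tolerated), three related compounds have been measured so far. Compound 1 `CCC[C@@H](/C=C/S(=O)(=O)c1ccccc1)NC(=O)c1cccc2cccnc12` stands at a limit of the assay, > 80000 nM, not at an exact number. Compound 2 `CCCC[C@@H](/C=C/S(=O)(=O)c1ccccc1)NC(=O)c1cccc2cccnc12` gives 36500 nM, and compound 3 `O=C(N[C@H](/C=C/S(=O)(=O)c1ccccc1)CCc1ccccc1)c1cccc2nccnc12` gives 39600 nM. These two values lie within the usual scatter of each other, so compound 3 stands level with compound 2 on the numbers available.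

The next compound, compound 4 `O=C(N[C@H](/C=C/S(=O)(=O)c1ccccc1)CCc1ccccc1)[C@@H]1CSCN1`, keeps the rest of compound 3 and changes one group: 1,3-thiazolidin-4-yl in place of quinoxalin-5-yl on a carbonyl carbon. In words, 1,3-thiazolidin-4-yl stands in place of quinoxalin-5-yl on a carbonyl carbon.

Within the data shown here, the only measured step, methyl in place of hydrogen on a saturated chain carbon, gave an at least 2.1-fold lower number from compound 1 to compound 2 (0.34 log units; beyond the scatter), so the smaller group in compound 4 is expected to raise the number only slightly, if at all. The support is thin, since that step is a different change at a different place. The expected size of the change is a 1.5-fold higher number from compound 3 to compound 4 (0.18 log units; within the scatter). For compound 4 the estimated value is 60000 nM, with an expected range from 25000 nM to 120000 nM.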

Compound 4, half-maximal cytotoxic concentration: 77800 nM
Estimate against measurement, compound 4: 1.3-fold (0.11 log units) below, within the range that was stated.
By their numbers in this assay, from the lowest: compounds 2, 3 and 4 (each within the scatter of the next, the first and the last beyond it). At a limit, above all of these: compound 1.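

In this assay, among these compounds, the one earlier step concerned a saturated chain, whereas this result gives the first reading for the group on the carbonyl carbon, and it is a 2.0-fold higher number from compound 3 to compound 4 (0.29 log units; within the scatter). So, at this place and with the rest of the molecule unchanged, quinoxalin-5-yl, with 10 heavy atoms and two aromatic rings, can be exchanged for 1,3-thiazolidin-4-yl, with 5 heavy atoms, one non-aromatic ring and a defined stereocentre, without a difference that can be told from repeat-measurement noise. Any further exchange at this place would have little room to be read as an exact number, as the assay ends at a limit: the limit of > 80000 nM in this assay, at which 1 of the 4 values shown sits.

Open, as far as these compounds go, is whether the sulfur of the ring matters, which a pyrrolidin-2-yl ring with carbon in its place could test, and whether the mirror-image stereocentre on the 1,3-thiazolidin-4-yl ring would give the same reading. Also open, from the compounds shown here alone, is how a simple amine or a carboxylic acid on the ring would behave, and whether 1,3-thiazolidin-4-yl would read the same on the shorter saturated chains of compound 1 and compound 2.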